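Fluoro to Methoxy Swap Carried onto a Second Core

A few compounds are considered here, and "the series" means these few. Any claim that something is new, unique, unknown or untested is made for them only; others in the source may bear on it.

Compound 1 `COc1ccc(-c2nn(-c3ccc(S(N)(=O)=O)cc3)cc2C(CC(=O)c2ccc(Cl)cc2)C(=O)c2ccc(F)cc2)cc1` and compound 3 `Cc1ccc(-c2nn(-c3ccc(S(N)(=O)=O)cc3)cc2-c2cc(-c3ccc(Cl)cc3)[nH]c2-c2ccc(F)cc2)cc1` carry the same fluoro group on different cores; the difference between the two cores is not broken down here. In a functional assay on the whole organism (strain Wistar albino) for inhibition, with Rattus norvegicus as the target, read by paw edema, with stated times of 1 h and 3 h, at a dose of 0.32 mmol/kg by the intraperitoneal route (a higher number here means more inhibition at the dose given (going by the name of the read-out), a lower number less inhibition), compound 1 gives 68.1% and compound 3 gives 66.7%, two numbers within the usual scatter of each other. Among the compounds with values here, compound 2 `COc1ccc(C(=O)C(CC(=O)c2ccc(Cl)cc2)c2cn(-c3ccc(S(N)(=O)=O)cc3)nc2-c2ccc(OC)cc2)cc1` is compound 1 with methoxy in place of fluoro on an aromatic carbon; in this assay compound 2 gives 22.5%, and the step of a number 45.6 percentage points lower from compound 1 to compound 2 (beyond the scatter) is the only measured reading of this change. Compound 4 `COc1ccc(-c2[nH]c(-c3ccc(Cl)cc3)cc2-c2cn(-c3ccc(S(N)(=O)=O)cc3)nc2-c2ccc(C)cc2)cc1` is not yet measured; it is compound 3 with methoxy in place of fluoro on an aromatic carbon. The surroundings differ: in compound 1 the difference cut one bond further out also reads (4-fluorophenyl)carbonyl to (4-methoxyphenyl)carbonyl, whereas in compound 3 it reads only 4-fluorophenyl to 4-methoxyphenyl, so this is the same kind of change, not the same change. The step to compound 4 is expected to be a number 31.7 percentage points lower from compound 3 to compound 4 (beyond the scatter) in this assay, smaller than the earlier one because a number 45.6 percentage points lower from compound 1 to compound 2 (beyond the scatter) rests on a single pair on a different core. Compound 4 is expected to give 35%, within a range from 15% to 58%.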

Compound 4, a percentage reported as inhibition, in the whole organism at one dose (the size of the read-out at that dose, not a potency): 34.2%
Compound 4: the middle estimate sits 0.8 percentage points above what was measured; low and high end bracket the measured number.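

In this assay, methoxy in place of fluoro on an aromatic carbon also gives a large step on the second core, a number 32.5 percentage points lower from compound 3 to compound 4 (beyond the scatter), so the change carries over in direction and the two steps cannot be told apart in size: the same change on two cores in this assay, a number 45.6 percentage points lower (beyond the scatter) from compound 1 to compound 2 and a number 32.5 percentage points lower (beyond the scatter) from compound 3 to compound 4, 13.1 percentage points apart, within the scatter of two such steps

This rests on two pairs only, and on the core of compound 1 the change also reads (4-fluorophenyl)carbonyl to (4-methoxyphenyl)carbonyl, whereas on the core of compound 3 it reads 4-fluorophenyl to 4-methoxyphenyl, so the agreement covers the same kind of change and not an identical one. It gives no general rule for other cores, offers no explanation for the step, and describes inhibition at one dose rather than potency.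

The compounds shown leave open how far the step depends on the methoxy group itself. A hydroxy group, an amine or a longer ethoxy chain in the same place, or a plain unsubstituted phenyl, would be needed to settle this on either core.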